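A Fluorobenzyl Swap Beyond the Assay Limit

The source may hold more compounds than are shown below. What is called first, only, known or untested is meant among the compounds shown, and "the series" means these compounds.

In a functional assay on cells (Platelet, Homo sapiens) for inhibition (a higher number here means a weaker inhibitor, a lower number a stronger inhibitor), compound 1 `CCOC(=O)c1ccc(-c2nn(Cc3ccccc3Cl)c3ccccc23)cc1` gives > 10000 nM, a limit and not a number. Compound 2 `CCOC(=O)c1ccc(-c2nn(Cc3ccc(Cl)cc3)c3ccccc23)cc1` gives > 10000 nM, also only a limit. Together they mark (the limit of > 10000 nM in this assay, at which 2 of the 2 values shown sit). Among the compounds with values here, the sole measured step, a step that the two limits leave unreadable from compound 1 to compound 2, has no readable size. Compound 3 `CCOC(=O)c1ccc(-c2nn(Cc3cccc(F)c3)c3ccccc23)cc1` carries 3-fluorophenyl in place of 4-chlorophenyl on a saturated chain carbon bound to an aromatic nitrogen. Within the data shown here, with no sized step to draw on, no clear change in either direction is expected, and the expected move is a step that the limit leaves unreadable from compound 2 to compound 3. Compound 3 is estimated at 15000 nM, with an expected range of 5000 nM to 50000 nM.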

Compound 3, half-maximal inhibitory concentration: > 10000 nM
Compound 3: only a limit was reported; the forecaster's own chance of this, stated with the estimate: 80%; the middle value does not contradict the limit.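

Within the data shown here, compound 3, like compound 1 and compound 2, is reported only as a limit in this assay, so no step among the three can be read. The compounds shown leave open how strongly any of them inhibits, and whether changing the phenyl group alters that at all.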